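A few compounds are considered here, and "the series" means these few. Any claim that something is new, unique, unknown or untested is made for them only; others in the source may bear on it.

Measured so far in a functional assay on A549 cells (Homo sapiens) for antiproliferative activity, read by MTT assay, with a stated time of 72 h; a higher number here means a weaker inhibitor, a lower number a stronger inhibitor:

compound 1, `COc1cc(C(=O)c2sc3ccccc3c2-c2ccc(C)cc2)cc(OC)c1OC`: 7800 nM
compound 2, `COc1ccc(-c2c(C(=O)c3cc(OC)c(OC)c(OC)c3)sc3ccccc23)cc1`: 4400 nM
compound 3, `COc1cc(C(=O)c2sc3ccccc3c2Nc2ccc(C)cc2)cc(OC)c1OC`: 2600 nM

Compound 1 and compound 2 share a core and differ by methoxy in place of methyl on an aromatic carbon. The step is a 1.8-fold lower number from compound 1 to compound 2 (0.25 log units; within the scatter). Compound 2 and compound 3 differ in two places at once; the step is a 1.7-fold lower number from compound 2 to compound 3 (0.23 log units; within the scatter), so no order between those two can be read from these numbers. Compound 3 has the lowest number of the three, and only its gap to compound 1 is beyond the scatter.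

Not yet measured: compound 4, `COc1ccc(Nc2c(C(=O)c3cc(OC)c(OC)c(OC)c3)sc3ccccc23)cc1`. It differs from compound 3 by methoxy in place of methyl on an aromatic carbon. This is the same change already seen from compound 1 to compound 2, with the place described in the same words; it is now made on the core of compound 3 rather than that of compound 1. The two cores differ by (4-methylphenyl)amino in place of 4-methylphenyl on an aromatic carbon, a difference that gave a 3.0-fold lower number from compound 1 to compound 3 (0.48 log units; beyond the scatter).

Compound 4 is expected to give about 1500 nM in this assay. For compound 4 the expected range is 700 nM to 3500 nM. The expected step of a 1.7-fold lower number from compound 3 to compound 4 (0.24 log units; within the scatter) is set to match the step of a 1.8-fold lower number from compound 1 to compound 2 (0.25 log units; within the scatter) on the other core; whether the change carries over to the core of compound 3 is not known from these three compounds, and the earlier step itself was within the scatter, so the range is kept wide.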

Compound 4, half-maximal inhibitory concentration: 9300 nM
The estimate for compound 4 lay 6.2-fold (0.79 log units) below the measured number; measured number outside the range, above it.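

Methoxy in place of methyl does not carry over from one core to the other in this assay, and the two steps differ in direction as well as size: the same change on two cores in this assay, a 1.8-fold lower number (0.25 log units; within the scatter) from compound 1 to compound 2 and a 3.6-fold higher number (0.55 log units; beyond the scatter) from compound 3 to compound 4, 6.3-fold (0.80 log units) apart, beyond the scatter of two such steps. Read on the core of compound 3 alone, the change gives a 3.6-fold higher number from compound 3 to compound 4 (0.55 log units; beyond the scatter), and the exchange of core also depends on the group present: (4-methylphenyl)amino in place of 4-methylphenyl gives a 3.0-fold lower number from compound 1 to compound 3 (0.48 log units; beyond the scatter), (4-methoxyphenyl)amino in place of 4-methoxyphenyl gives a 2.1-fold higher number from compound 2 to compound 4 (0.33 log units; beyond the scatter), and (4-methoxyphenyl)amino in place of 4-methylphenyl gives a 1.2-fold higher number from compound 1 to compound 4 (0.08 log units; within the scatter). This shows that, for these four compounds, a step on one core is a poor guide to the same step on the other, but it rests on a single pair of steps, one of them within the scatter, and it gives no reason for the difference and no rule for other groups.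

Still open, as far as these compounds go, is whether a chlorine, a hydroxyl, an ethyl or a dimethylamino group at the same place, para to a large group, would also give steps that differ between the two cores. Also open, from the compounds shown here alone, is whether the same holds in cell lines other than A549.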